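Chloro for fluoro on the phenoxy ring of compound 3

The compounds below may be only part of what the source reports. "The series", "measured", "known", "first", "only" and "open" are said of these compounds alone.

Compound 3 `COC(=O)c1ccc(-c2nnn(CC(=O)C(C)Oc3ccc(Oc4ccc(F)cc4)cc3)n2)cc1` has been measured in an ADME assay on S9 fraction from liver (Rattus norvegicus) for metabolic stability, read by LC-MS, using NADPH, with a stated time of 30 min; on this read-out lower numbers stand for a less stable compound and higher numbers for a more stable compound. Compound 3 gives < 5%, which is a limit of the assay and not a number. Among the measured compounds shown here, compound 2 `CCCCCCCCc1ccc(OC(C)C(=O)Cn2nnc(-c3ccc(C(=O)OC)cc3)n2)cc1` gives 62%, and the step of a number at least 57 percentage points lower from compound 2 to compound 3 (beyond the scatter) is the only measured step that bears on compound 3; compound 3 sits at the limit of < 5% in this assay, at which 2 of the 3 values shown sit. Compound 1 `CC(Oc1ccc(Oc2ccc(Cl)cc2)cc1)C(=O)Cn1nnc(-c2ccccc2)n1` gives < 5%, again a limit of the assay. Compound 4 `COC(=O)c1ccc(-c2nnn(CC(=O)C(C)Oc3ccc(Oc4ccc(Cl)cc4)cc3)n2)cc1` differs from compound 3 by chloro in place of fluoro on an aromatic carbon. For the measured compounds named here, no measured step covers this exchange; compound 1 carries the same 4-chlorophenoxy and its value is a limit. Compound 4 is therefore expected to stay at the limit, with an expected step that the limit leaves unreadable from compound 3 to compound 4, none beyond the scatter. Compound 4 is estimated at 3%, expected between 0% and 10%.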

Compound 4, percent of the compound remaining in the Rattus norvegicus assay: < 5%
Compound 4 was reported as a limit; the forecaster's own chance of this, stated with the estimate: 85%; the middle value is on the limit's open side.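

In the Rattus norvegicus assay, 4-chlorophenoxy in place of octyl gives a number at least 57 percentage points lower from compound 2 to compound 4 (beyond the scatter), so the drop seen with 4-fluorophenoxy recurs with a second halogen. The steps from compound 3 and from compound 1 to compound 4 cannot be read, as both ends of each are limits. In a physicochemical assay for lipophilicity, read by HPLC, tested at 5 mM (on this read-out lower numbers stand for lower lipophilicity and higher numbers for higher lipophilicity), compound 3 gives 5.4 and compound 4 gives 6.1. Chloro in place of fluoro does separate the pair in the physicochemical assay: the measured partition coefficient of compound 3, 5.4, and of compound 4, 6.1, a number 0.70 log units higher (beyond the scatter)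

Open, on these data alone, is whether any group other than octyl at this place, such as a butyl chain or a carboxylic acid, lifts the series off the limit. Also open, as far as these compounds go, is what methoxycarbonyl contributes once a compound stands clear of it.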